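Trifluoromethoxy in place of trifluoromethyl in a growth-inhibitor series

The source may report more compounds than this note shows. Statements on the series, on what has been measured and on what is new or still open speak of the compounds shown alone.

compound 1 `Oc1cccc2[nH]c(-c3ccc(-c4ccc(-c5ccc(F)cc5)cc4)cc3)nc12`: 3010 nM
compound 2 `Oc1cccc2[nH]c(-c3ccc(-c4ccc(-c5ccc(C(F)(F)F)cc5)cc4)cc3)nc12`: 2310 nM

Going by the values given here, in a functional assay on MCF7 cells (Homo sapiens) for inhibition, read by sulforhodamine B assay (a higher number here means a weaker inhibitor of growth, a lower number a stronger inhibitor of growth), compound 2 lies within the scatter of compound 1, the only other measured compound. Compound 3 `Oc1cccc2[nH]c(-c3ccc(-c4ccc(-c5ccc(OC(F)(F)F)cc5)cc4)cc3)nc12` differs from compound 2 by trifluoromethoxy in place of trifluoromethyl on an aromatic carbon. Among the compounds with values here, the one measured step that bears on this, a 1.3-fold lower number from compound 1 to compound 2 (0.11 log units; within the scatter), was likewise a swap of groups on an aromatic carbon, so no step beyond the scatter is expected in this assay. The estimated step is a 1.1-fold higher number from compound 2 to compound 3 (0.03 log units; within the scatter). Compound 3 is expected at 2500 nM, within an estimated range of 1200 nM to 5000 nM.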

Compound 3, concentration for 50% growth inhibition: 2210 nM
The estimate for compound 3 lay 1.1-fold (0.05 log units) above the measured number; measured number inside the range.
By their numbers in this assay, from the lowest: compounds 3, 2 and 1 (each within the scatter of the next).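

In this assay, putting trifluoromethoxy on this aromatic carbon, para to a large group, gives a 1.0-fold lower number from compound 2 to compound 3 (0.02 log units; within the scatter) and, measured against fluoro, gives a 1.4-fold lower number from compound 1 to compound 3 (0.13 log units; within the scatter) as well. Together with the earlier step, this places all three groups at this position within the scatter of one another, even though trifluoromethoxy adds an oxygen and a hydrogen-bond acceptor. Nothing measured alongside these numbers explains this sameness.

All three groups contain fluorine. From the compounds shown here alone, whether an amine, a carboxylic acid or a longer chain at this position would give a number beyond the scatter remains open.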